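The source may hold more compounds than are shown below. What is called first, only, known or untested is meant among the compounds shown, and "the series" means these compounds.

Two compounds of this series have been examined in an assay for inhibition of steroid 17-alpha-hydroxylase/17,20 lyase (Homo sapiens), tested at 0.2 uM; on this read-out lower numbers stand for a weaker effect and higher numbers for a stronger effect at the one concentration tested. Compound 1 `COc1ccc2cc(-c3ccc(F)cc3)ccc2c1-c1cccnc1` carries a methoxy group and a pyridinyl group on its core, and in this assay compound 1 gives 6%. Compound 2 `Fc1ccc(-c2ccc3c(Cn4ccnc4)cccc3c2)cc1` carries a (1H-imidazol-1-yl)methyl group and no methoxy group, and in this assay compound 2 gives 2%. Compound 2 thus stands at the lowest of the two numbers recorded, but the gap to compound 1 lies within the scatter, so the two readings cannot be told apart. Compound 3 `COc1ccc2cc(-c3ccc(F)cc3)ccc2c1Cn1ccnc1` is the result of a single change on compound 2: methoxy in place of hydrogen on an aromatic carbon. The same methoxy group is present in compound 1, whose reading of 6% is low as well, so nothing in the two measured numbers points to a large effect of this change. The expected step is small, a number 2 percentage points higher from compound 2 to compound 3 (within the scatter), and not beyond the scatter in either direction. For compound 3 the estimate in this assay is therefore 4%, with a range from -5% to 15%.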

Compound 3, a percentage reported as inhibition, at one concentration (the size of the read-out at that concentration, not a potency): 13%
Compound 3: the middle estimate sits 9 percentage points below what was measured; the measured number falls inside the stated range.
By their numbers in this assay, from the lowest: compounds 2, 1 and 3 (each within the scatter of the next, the first and the last beyond it).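

At the aromatic carbon ortho to the (1H-imidazol-1-yl)methyl group, methoxy in place of hydrogen gives in this assay a number 11 percentage points higher from compound 2 to compound 3 (beyond the scatter) and so provides the first modest difference in this series that can be read, which the two earlier readings, lying within the scatter of each other, could not offer. With the methoxy group held constant, (1H-imidazol-1-yl)methyl in place of pyridin-3-yl on an aromatic carbon gives a number 7 percentage points higher from compound 1 to compound 3 (within the scatter) and thus shows no readable difference between these two groups at this place in this assay. The data shown include no independent measurement that bears on the origin of the methoxy step.

The compounds shown leave open whether the step belongs to methoxy itself or would also appear with a hydroxyl, an ethoxy group, a fluorine atom or a longer alkoxy chain on the same carbon. They also leave open how the pyridin-3-yl group behaves with hydrogen in place of methoxy, and whether an amine or a carboxylic acid at this carbon would give a reading clearly apart from that of compound 3.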